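The source may hold more compounds than are shown below. What is called first, only, known or untested is meant among the compounds shown, and "the series" means these compounds.

Measured so far in an ADME assay on the whole organism (Rattus norvegicus, strain Sprague-Dawley) for pharmacokinetics, using cassette dosing, at a dose of 0.5 mg/kg by the intravenous route; on this read-out higher numbers stand for fast clearance and lower numbers for slow clearance:

Compound 1 `O=C(c1cc(-c2cn[nH]c2)on1)N1CCC(Cc2ccc(Cl)cc2)CC1` gives 29.2 mL/min/kg 
Compound 2 `O=C(Nc1ccc2[nH]c(=O)oc2c1)C(=O)N1CCN(c2ccc(F)cc2)CC1` gives 11.1 mL/min/kg 

Of these two numbers, compound 2 holds the lower one in this assay and compound 1 stands above it by a gap beyond the scatter. Compound 3 `O=C(Nc1ccc2[nH]c(=O)oc2c1)C(=O)N1CCN(c2ccc(F)c(Cl)c2)CC1` is compound 2 with one change (chloro in place of hydrogen on an aromatic carbon) that places chloro in place of hydrogen on an aromatic carbon, ortho to a fluoro group and meta to a large group. In this way, 4-fluorophenyl becomes 3-chloro-4-fluorophenyl. Within the data shown here, no measured pair shows such a change, and no step beyond the scatter is expected in this assay for it. The expected step is a 1.1-fold higher number from compound 2 to compound 3 (0.03 log units; within the scatter) and it is estimated to stay within the scatter, with no firm direction. The number expected for compound 3 is 12 mL/min/kg with an estimated range from 6 mL/min/kg to 24 mL/min/kg around it.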

Compound 3, clearance: 18.3 mL/min/kg
Beside the measured number, compound 3's estimate is 1.5-fold (0.18 log units) below it; measured number inside the range.
By their numbers in this assay, from the lowest: compounds 2, 3 and 1 (each within the scatter of the next, the first and the last beyond it).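

In this assay, among these compounds, chloro in place of hydrogen on an aromatic carbon, ortho to a fluoro group and meta to a large group, gives a 1.6-fold higher number from compound 2 to compound 3 (0.22 log units; within the scatter) and provides the first comparison of compounds that differ in one place. At this position of the shared core, therefore, the change from 4-fluorophenyl to 3-chloro-4-fluorophenyl leaves clearance within the usual scatter and shows no firm direction. Nothing available explains this result or ties it to any property of the chloro group.

The compounds shown leave open whether a methoxy group, a nitrile, trifluoromethyl or an amine at this same position would also stay within the scatter. They also leave open whether chloro on another carbon of this ring would read the same way.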